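A Methoxy for a Chloro in a Series at the Limit

The source may hold more compounds than are shown below. What is called first, only, known or untested is meant among the compounds shown, and "the series" means these compounds.

compound 1 `CC(C)(C)OC(=O)N1CCN(C(=S)SCc2cn(Cc3ccc(Cl)cc3)nn2)CC1`: > 128000 nM
compound 2 `COc1cc(Cn2cc(CSC(=S)N3CCNCC3)nn2)cc(OC)c1OC`: > 128000 nM
compound 3 `CC(C)(C)OC(=O)N1CCN(C(=S)SCc2cn(Cc3cc(=O)oc4cc(O)ccc34)nn2)CC1`: > 128000 nM

All three values come from a functional assay on ECa-109 cells (Homo sapiens) for inhibition, read by MTT assay, with a stated time of 72 h; a lower number here means a stronger inhibitor, a higher number a weaker inhibitor. For compound 1 the figure is a limit of the assay, not a number. The same is true of compound 2. The same is true of compound 3. Compound 1 therefore stands exactly where every measured compound stands, at the point described by the limit of > 128000 nM in this assay, at which 3 of the 3 values shown sit, and on the numbers shown nothing separates it from compound 2 or compound 3.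

Compound 4 `COc1ccc(Cn2cc(CSC(=S)N3CCN(C(=O)OC(C)(C)C)CC3)nn2)cc1` has not yet been measured in this assay. It differs from compound 1 by methoxy in place of chloro on an aromatic carbon. Going by the values given here, no measured pair shows this change, so its effect rests on expectation alone. Because all three measured compounds sit at the limit recorded in the limit of > 128000 nM in this assay, at which 3 of the 3 values shown sit, the expected step that the limit leaves unreadable from compound 1 to compound 4 is no change beyond the scatter. Compound 4 is estimated at 160000 nM, with a range from 40000 nM to 640000 nM, and this assay is expected most likely to report only a limit again for compound 4.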

Compound 4, half-maximal inhibitory concentration: 36800 nM
Estimate against measurement, compound 4: 4.3-fold (0.64 log units) above; measured number outside the range, below it.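

In this assay, going by these compounds alone, methoxy in place of chloro on an aromatic carbon, para to a large group, gives an at least 3.4-fold lower number from compound 1 to compound 4 (0.54 log units; beyond the scatter), so this position of the 4-chlorobenzyl group can affect the read-out, which the earlier compounds could not show. Compound 4, at 36800 nM, is the only compound shown with a number rather than a limit, and it gives the series its first measured point. The step can be given only as a minimum because its starting value is a limit of the assay: the limit of > 128000 nM in this assay, at which 3 of the 4 values shown sit.

The compounds shown leave open how a hydroxyl, an amine or a carboxylic acid at this position would read. They also leave open whether methoxy at another carbon of that ring would give a number at all.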